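The source may hold more compounds than are shown below. What is called first, only, known or untested is meant among the compounds shown, and "the series" means these compounds.

Measured compounds in a toxicity assay on MRC5 cells (Homo sapiens) for inhibition, read by MTT assay, with a stated time of 72 h; on this read-out lower numbers stand for stronger inhibition and higher numbers for weaker inhibition:
Compound 1 `CC(=O)OCCc1ccc(O)c(O)c1` gives > 50000 nM; this is a limit of the assay, not a number.
Compound 2 `CCCCCCCCCCCCCC(=O)OCCc1ccc(O)c(O)c1` gives > 50000 nM; this too is a limit of the assay, not a number.

Compound 2 therefore stands at no fixed place on the scale: for it only a limit is shown, and the one other value shown is a limit as well, so that both values rest at the limit of > 50000 nM in this assay, at which 2 of the 2 values shown sit. For the measured compounds named here, no step between two measured compounds can be drawn from such a pair, and nothing about the size of any change in this assay can be read from them.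

The step from compound 2 leads to compound 3 `CCCCCCCCCCC(=O)OCCc1ccc(O)c(O)c1`, which differs from it in one place: hydrogen in place of propyl on a saturated chain carbon, ten or more bonds along the chain from a carbonyl carbon. Going by the values given here, with no measured step to lean on, and with both values shown sitting at the same limit, the expected movement in this assay from compound 2 to compound 3 is none beyond the scatter, written as a number no higher from compound 2 to compound 3 (the limit leaves the size open). Compound 3 is estimated at 50000 nM, with a range from 20000 nM to 150000 nM, and most likely the assay will again report only a limit.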

Compound 3, half-maximal inhibitory concentration: > 50000 nM
Compound 3: a limit, no number; the forecaster's own chance of this, stated with the estimate: 85%; the middle value sits exactly at the limit.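

In this assay compound 3 gives > 50000 nM, which is a limit of the assay and not a number. Compound 2 also sits at a limit, so no step can be read between compound 2 and compound 3: the limit of > 50000 nM in this assay, at which 3 of the 3 values shown sit.

The compounds shown leave open how strongly any of them acts in this assay, and whether the length of the chain matters there at all.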